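Sulfonamide piperidines: cytotoxicity sitting at the assay limit

The source may hold more compounds than are shown below. What is called first, only, known or untested is meant among the compounds shown, and "the series" means these compounds.

Three measured compounds belong to the series: compound 1 `CCCC(=O)N(Cc1ccccc1)C1CCN(S(=O)(=O)c2c(C)cc(C)cc2C)CC1`, compound 2 `CC1CCN(C2CCN(S(=O)(=O)c3ccc(-c4ccccc4F)cc3)CC2)CC1` and compound 3 `Cc1cc(C)c(S(=O)(=O)N2CCC(N3CCCCC3)CC2)c(C)c1`. All three were run in an ADME assay on HCT-116 cells (Homo sapiens) for cytotoxicity, read by CellTiter-Glo, with a stated time of 72 h (a lower number here means a stronger inhibitor, a higher number a weaker inhibitor), and none returned a number. In this assay compound 1 gives only a limit, > 5000 nM. Compound 2 likewise gives only a limit in this assay, > 5000 nM. For compound 3 the reading in this assay is again a limit, > 5000 nM. The picture is therefore uniform: the limit of > 5000 nM in this assay, at which 3 of the 3 values shown sit. Compound 2 thus stands nowhere in particular among the numbers shown; it shares the limit with compound 1 and compound 3, and no ordering among the three can be drawn from it. Among the compounds with values here, with no pair of measured compounds differing in a single place, no measured step size is available.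

Compound 4 `CC1CCN(C2CCN(S(=O)(=O)c3ccc(C(C)(C)C)cc3)CC2)CC1` is the next compound to be measured in this assay. Relative to compound 2 the change is tert-butyl in place of 2-fluorophenyl on an aromatic carbon. The expectation for this assay is a step that the limit leaves unreadable from compound 2 to compound 4, that is, nothing beyond the usual scatter, with the reading most probably again only a limit. Compound 4 is estimated at 10000 nM, with a range from 4000 nM to 30000 nM.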

Compound 4, half-maximal inhibitory concentration: > 5000 nM
Compound 4: only a limit was reported (the forecaster's own chance of this, stated with the estimate: 85%); the middle value lies beyond the limit too.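

Within the data shown here, compound 4 gives only a limit in this assay, > 5000 nM, and compound 2 is also a limit, so no step between these two compounds can be read for tert-butyl in place of 2-fluorophenyl. The compounds shown leave open whether any member of the series has a measurable cytotoxicity, with every reading at one limit: the limit of > 5000 nM in this assay, at which 4 of the 4 values shown sit.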